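A smaller group on the sulfur of compound 1

This account rests on a few compounds, and the source may have more. Where it says the series, first, only, none or still open, it means among the compounds named here.

In an ADME assay (liver) for metabolic stability, with Liver microsome (Rattus norvegicus) as the target, using microsomes, with a stated time of 30 min, tested at 1 uM (a higher number here means faster removal of the compound, a lower number slower removal), compound 1 `O=C(CCSc1nc2ccccc2c(=O)[nH]1)N[C@H]1CC[C@H](c2nnc(-c3ccccc3)o2)CC1` gives 57 mL.min-1.g-1, the lower of the two numbers available. Compound 2 `O=C(N[C@H]1CC[C@H](c2nnc(-c3ccccc3)o2)CC1)[C@@H]1CCCN(Cc2nc3ccccc3c(=O)[nH]2)C1` gives 206 mL.min-1.g-1, a gap beyond the scatter, although the two structures differ in more than one place. Compound 3 `O=C(CCSc1nccc(=O)[nH]1)N[C@H]1CC[C@H](c2nnc(-c3ccccc3)o2)CC1` changes the group on a sulfur whose other neighbour is a saturated chain carbon: a group of 7 heavy atoms (4 carbon, 2 nitrogen, 1 oxygen; one six-membered aromatic ring with 2 hetero atoms) in place of a group of 11 heavy atoms (8 carbon, 2 nitrogen, 1 oxygen; one six-membered aromatic ring of carbon only, one six-membered aromatic ring with 2 hetero atoms), on a sulfur. The six-membered aromatic ring of carbon only leaves, and a six-membered aromatic ring with 2 hetero atoms remains in the group that enters. For the measured compounds named here, no measured pair shows this change, so the expectation rests on compound 1 at 57 mL.min-1.g-1. A small move towards a lower number is expected, not beyond the scatter in this assay: a 1.4-fold lower number from compound 1 to compound 3 (0.15 log units; within the scatter). For compound 3 the estimated value is 40 mL.min-1.g-1, with an expected range of 15 mL.min-1.g-1 to 100 mL.min-1.g-1.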

Compound 3, intrinsic clearance in microsomes: < 14 mL.min-1.g-1
Compound 3: no number, only a limit; the forecaster's own chance of this, stated with the estimate: 3%; at least 2.8-fold (0.45 log units) between middle value and limit.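

Replacing the group on the sulfur, with the six-membered aromatic ring of carbon only leaving, gives an at least 4.0-fold lower number from compound 1 to compound 3 (0.60 log units; beyond the scatter) in this assay. This is the only step shown that differs in one place, and it shows that this position alone can move the number beyond the scatter, which the gap between the two earlier compounds, differing in more than one place, could not show. The step is a bound and not a measured size, as compound 3 has only a limit of the assay: the limit of < 14 mL.min-1.g-1 in this assay, at which 1 of the 3 values shown sits.

One step cannot separate the loss of that ring from the lower count of heavy atoms in the group. As far as these compounds go, how a methyl or a phenyl on the sulfur would stand in this assay, and what an amine in place of the sulfur would do, remains open.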